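The compounds below may be only part of what the source reports. "The series", "measured", "known", "first", "only" and "open" are said of these compounds alone.

Working notes on the series in a functional assay on RS4-11 cells (Homo sapiens) for inhibition, read by CCK-8 assay, with a stated time of 48 h; a higher number here means a weaker inhibitor, a lower number a stronger inhibitor.

Of the compounds shown here, three have numbers so far. Compound 1 `O=C(NCCNS(=O)(=O)c1ccc(-c2ccccc2OCc2cccc(O)c2)s1)Nc1cc(Cl)cc(Cl)c1` returns only a limit of the assay in this assay, namely > 50000 nM. Compound 3 `O=[N+]([O-])c1ccc(NC(=S)NCCNS(=O)(=O)c2ccc(-c3ccccc3OCc3cccc(O)c3)s2)cc1` gives 10100 nM in this assay. Compound 2 `CC(C)c1ccc(Oc2ccc(O)c(O)c2)c(-c2ccsc2S(=O)(=O)NCCNC(=S)Nc2ccc([N+](=O)[O-])cc2)c1` gives 5100 nM in this assay; its number and that of compound 3 lie within the usual scatter of each other, so no order between the two is claimed. Compound 2 and compound 3 are built on different cores; the difference between the two cores is not broken down here.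

One change has been made on a measured pair: a group of 11 heavy atoms (7 carbon, 1 nitrogen, 1 oxygen, 2 chlorine; one six-membered aromatic ring of carbon only) in place of a group of 12 heavy atoms (7 carbon, 2 nitrogen, 2 oxygen, 1 sulfur; one six-membered aromatic ring of carbon only), on an amine nitrogen. In this assay it produced an at least 4.9-fold higher number from compound 3 to compound 1 (0.69 log units; beyond the scatter), the size of the step resting on (the limit of > 50000 nM in this assay, at which 1 of the 3 values shown sits), so only its lower bound is known.

Compound 4 `CC(C)c1ccc(Oc2ccc(O)c(O)c2)c(-c2ccsc2S(=O)(=O)NCCNC(=O)Nc2cc(Cl)cc(Cl)c2)c1` has not yet been measured in this assay. It carries the same change relative to compound 2: a group of 11 heavy atoms (7 carbon, 1 nitrogen, 1 oxygen, 2 chlorine; one six-membered aromatic ring of carbon only) in place of a group of 12 heavy atoms (7 carbon, 2 nitrogen, 2 oxygen, 1 sulfur; one six-membered aromatic ring of carbon only), on an amine nitrogen. The place is described in identical words for both pairs, so this is taken as the same change.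

From compound 2 to compound 4 a step of about a 6.9-fold higher number from compound 2 to compound 4 (0.84 log units; beyond the scatter) is expected in this assay, resting on the step of an at least 4.9-fold higher number from compound 3 to compound 1 (0.69 log units; beyond the scatter) seen with the same change, with the reservation that the earlier step is bounded only by the limit for compound 1.

For compound 4 an estimate of 35000 nM in this assay is therefore put down, with a likely range from 10000 nM to 120000 nM, and a fair chance that only a limit is returned.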

Compound 4, half-maximal inhibitory concentration: 6400 nM
Compound 4: middle estimate off by 5.5-fold (0.74 log units), on the high side; measured number outside the range, below it.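

In this assay the change to (3,5-dichlorophenyl)carbamoyl on the amine nitrogen gives a 1.3-fold higher number from compound 2 to compound 4 (0.10 log units; within the scatter), so no order between these two compounds is claimed on this core. The change therefore does not carry over with the same size from one core to the other: the same change on two cores in this assay, an at least 4.9-fold higher number (0.69 log units; beyond the scatter) from compound 3 to compound 1 and a 1.3-fold higher number (0.10 log units; within the scatter) from compound 2 to compound 4, at least 3.9-fold (0.59 log units) apart, beyond the scatter of two such steps. Compound 1 stands at a limit, so the earlier step and the gap between the steps are known only as lower bounds, and with one pair on each core nothing shows which feature of the cores sets the steps apart: the limit of > 50000 nM in this assay, at which 1 of the 4 values shown sits.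

Each pair exchanges the thiocarbonyl for a carbonyl and the nitro-bearing phenyl for a dichlorophenyl together, so the compounds shown leave open what each of these two exchanges contributes on either core. Also open, as far as these compounds go, is how an unsubstituted phenyl, or a phenyl carrying a carboxylic acid, would behave in the same place on the two cores.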